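The source may report more compounds than this note shows. Statements on the series, on what has been measured and on what is new or still open speak of the compounds shown alone.

Compound 1 `FC(F)(F)c1ccc(CSc2nc(N3CCCCC3)c3ccccc3n2)cc1` carries a piperidin-1-yl group on the shared core. In a functional assay on MCF7 cells (Homo sapiens) for cytotoxicity, read by MTT assay, with a stated time of 72 h (on this read-out lower numbers stand for stronger inhibition and higher numbers for weaker inhibition), compound 1 reports only the assay limit, > 50000 nM. Compound 2 `FC(F)(F)c1ccc(CSc2nc(Nc3ccccc3C(F)(F)F)c3ccccc3n2)cc1` carries a (2-(trifluoromethyl)phenyl)amino group in its place. In this assay compound 2 likewise reaches only the limit, > 50000 nM. Going by the values given here, compound 3 `FC(F)(F)c1ccc(CSc2nc(Nc3cccc(Br)c3)c3ccccc3n2)cc1` carries a (3-bromophenyl)amino group, and in this assay compound 3 gives 25600 nM, the only number in the set. The two other values sit at the limit of > 50000 nM in this assay, at which 2 of the 3 values shown sit. The steps of an at least 1.9-fold lower number from compound 1 to compound 3 (0.29 log units; that floor lies within the scatter) and an at least 1.9-fold lower number from compound 2 to compound 3 (0.29 log units; that floor lies within the scatter) are both floors that stay within the scatter, and the step that the two limits leave unreadable from compound 1 to compound 2 cannot be read between two limits.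

Compound 4 `FC(F)(F)c1ccc(CSc2nc(Nc3ccc(C(F)(F)F)cc3)c3ccccc3n2)cc1` differs from compound 3 by 4-(trifluoromethyl)phenyl in place of 3-bromophenyl on a nitrogen on an aromatic ring. Among the compounds with values here, the steps that bear on it are the two floors into compound 3, neither of which clears the scatter, and the one other aryl amine, compound 2, sits at the limit. For compound 4 a step of a 1.5-fold higher number from compound 3 to compound 4 (0.17 log units; within the scatter) toward a weaker number is expected, with a real chance that only a limit is reported. Compound 4 is estimated at 38000 nM in this assay, in the range 15000 nM to 100000 nM.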

Compound 4, half-maximal inhibitory concentration: 5100 nM
For compound 4 the middle estimate is 7.5-fold (0.87 log units) above the measured one; the measured number lies below the stated range.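

In this assay, going by these compounds alone, the step of a 5.0-fold lower number from compound 3 to compound 4 (0.70 log units; beyond the scatter) is the first with a measured value at both ends and the first to clear the scatter, so the aryl group on this nitrogen can change the read-out. With the trifluoromethyl group retained, 4-(trifluoromethyl)phenyl in place of 2-(trifluoromethyl)phenyl gives an at least 9.8-fold lower number from compound 2 to compound 4 (0.99 log units; beyond the scatter), and (4-(trifluoromethyl)phenyl)amino in place of piperidin-1-yl gives an at least 9.8-fold lower number from compound 1 to compound 4 (0.99 log units; beyond the scatter). Both of these steps are floors, with the values of compound 1 and compound 2 being limits and not numbers: the limit of > 50000 nM in this assay, at which 2 of the 4 values shown sit.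

As far as these compounds go, whether the step into compound 4 follows the group or its place on the ring stays open, and 3-(trifluoromethyl)phenyl or 4-bromophenyl on the same nitrogen would separate the two. From the compounds shown here alone, how far the read-out moves with other groups on that ring, such as a methoxy group or a carboxylic acid, also remains unknown.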